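A Small Swap at the Edge of Detection

The compounds below may be only part of what the source reports. "The series", "measured", "known", "first", "only" and "open" are said of these compounds alone.

Compound 1 `Oc1cc(O)cc(-c2cn(-c3ccc(OC(F)(F)F)cc3)nn2)c1` was examined in a functional assay on MDA-MB-231 cells (Homo sapiens) for cytotoxicity, read by MTT assay; on this read-out lower numbers stand for stronger inhibition and higher numbers for weaker inhibition. In this assay compound 1 gives > 10000 nM, which is a limit of the assay rather than a measured number. For the measured compounds named here, compound 2 `COc1cc(OC)cc(-n2cc(-c3ccc(OC)c(OC)c3)nn2)c1` is the only other compound with a value here. In this assay compound 2 gives > 1000 nM, again a limit rather than a number. Going by the values given here, both values therefore sit at limits, one at the limit of > 1000 nM in this assay, at which 1 of the 2 values shown sits, and one at the limit of > 10000 nM in this assay, at which 1 of the 2 values shown sits, so compound 1 stands among readings that tell only that potency is weak, and no step between two measured compounds can be sized.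

Compound 3 `COc1ccc(-n2cc(-c3cc(O)cc(O)c3)nn2)cc1` differs from compound 1 by methyl in place of trifluoromethyl on an oxygen on an aromatic ring. With compound 1 known only as a limit, the step from compound 1 to compound 3 is expected to stay within the scatter, estimated as a step that the limit leaves unreadable from compound 1 to compound 3, with no clear direction. Compound 3 is accordingly expected to give about 15000 nM in this assay, in a range from 4000 nM to 60000 nM, most likely reported again as a limit.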

Compound 3, half-maximal inhibitory concentration: > 10000 nM
Compound 3: only a limit was reported; the forecaster's own chance of this, stated with the estimate: 70%; the middle value is on the limit's open side.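

Compound 1 and compound 3 are both reported only as limits in this assay, so the step between them cannot be read from these results, in size or in direction. The compounds shown leave open how potent any of them truly is on these cells, and whether trifluoromethoxy or methoxy makes any difference to that.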